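The source may report more compounds than this note shows. Statements on the series, on what has been measured and on what is new or still open speak of the compounds shown alone.

In a functional assay on HT-29 cells (Homo sapiens) for inhibition, read by MTT assay (on this read-out lower numbers stand for stronger inhibition and higher numbers for weaker inhibition), three compounds have been measured. Compound 1 (`CCOC(=O)c1c(N)sc(C(=O)Nc2ccc(Cl)cc2)c1-c1ccccc1`) gives 190 nM, compound 2 (`N#Cc1c(N)sc(C(=O)Nc2ccccc2)c1-c1ccccc1`) gives 8390 nM, and compound 3 (`CCOC(=O)c1c(NC(=O)CC#N)sc(C(=O)Nc2ccccc2)c1-c1ccccc1`) gives 630 nM. Compound 3 therefore holds the middle of the three numbers: its number is higher than that of compound 1 and lower than that of compound 2, both gaps lying beyond the scatter. Compound 4 (`CCOC(=O)c1c(N)sc(C(=O)Nc2ccccc2)c1-c1ccccc1`) differs from compound 3 by one change, (hydrogen in place of (cyanomethyl)carbonyl on a nitrogen on an aromatic ring), with hydrogen in place of (cyanomethyl)carbonyl on a nitrogen on an aromatic ring. Within the data shown here, no measured pair shows this change. The expected step, a 1.1-fold higher number from compound 3 to compound 4 (0.05 log units; within the scatter), is estimated to stay within the scatter, with no firm direction. For compound 4 the estimated value is 700 nM, with an expected range of 200 nM to 2500 nM.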

Compound 4, half-maximal inhibitory concentration: 7490 nM
For compound 4 the middle estimate is 11-fold (1.03 log units) below the measured one; the measured number lies above the stated range.
By their numbers in this assay, from the lowest: compound 1; then compound 3; then compounds 4 and 2 (each within the scatter of the next).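

In this assay, the (cyanomethyl)carbonyl on the nitrogen on an aromatic ring proves to matter: hydrogen in its place gives a 12-fold higher number from compound 3 to compound 4 (1.08 log units; beyond the scatter). Hydrogen in place of chloro on an aromatic carbon also gives a large step, a 39-fold higher number from compound 1 to compound 4 (1.60 log units; beyond the scatter), whereas ethoxycarbonyl in place of cyano on an aromatic carbon stays within the scatter, at a 1.1-fold lower number from compound 2 to compound 4 (0.05 log units; within the scatter). Nothing at hand explains these steps. From the compounds shown here alone, whether an acetyl group on that nitrogen would do the same as (cyanomethyl)carbonyl remains open. So does whether a bromo or a methoxy group would match the chloro.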